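The source may report more compounds than this note shows. Statements on the series, on what has been measured and on what is new or still open speak of the compounds shown alone.

The compounds here share a common core and were tested in a functional assay on HT-29 cells (Homo sapiens) for cytotoxicity, read by MTT assay, with a stated time of 24 h; a higher number here means a weaker inhibitor, a lower number a stronger inhibitor. Compound 1 `COc1cccc(C=O)c1OCc1cn(CCCOc2ccc3ccc(=O)oc3c2)nn1` gives 13300 nM in this assay. Compound 2 `NS(=O)(=O)c1ccc(C/N=C/c2ccccc2OCc2cn(CCCOc3ccc4ccc(=O)oc4c3)nn2)cc1` gives 14300 nM. Compound 3 `NS(=O)(=O)c1ccc(C/N=C/c2cc(Br)ccc2OCc2cn(CCCOc3ccc4ccc(=O)oc4c3)nn2)cc1` gives 17700 nM. Among these three numbers compound 3 has the highest, yet its distance to compound 2 and to compound 1 stays within the scatter, so the three cannot really be told apart. Within the data shown here, the one measured step between close neighbours, a 1.2-fold higher number from compound 2 to compound 3 (0.09 log units; within the scatter), came with a bromo in place of hydrogen on an aromatic carbon and stayed within the scatter.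

Compound 4 `NS(=O)(=O)c1ccc(C/N=C/c2cc([N+](=O)[O-])ccc2OCc2cn(CCCOc3ccc4ccc(=O)oc4c3)nn2)cc1` differs from compound 3 by nitro in place of bromo on an aromatic carbon. Among the measured compounds shown here, only the step from compound 2 to compound 3 touches the same place on the ring, and it moved nothing beyond the scatter; no measured step swaps bromo for nitro anywhere. The expectation for compound 4 is therefore a step of a 1.1-fold lower number from compound 3 to compound 4 (0.04 log units; within the scatter), meaning no change beyond the scatter. Compound 4 is estimated at 16000 nM in this assay, within a range from 7000 nM to 36000 nM.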

Compound 4, half-maximal inhibitory concentration: 117000 nM
Compound 4: middle estimate off by 7.3-fold (0.86 log units), on the low side; the whole stated range lies below it.
By their numbers in this assay, from the lowest: compounds 1, 2 and 3 (each within the scatter of the next); then compound 4.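

Among these compounds, at this aromatic carbon, the earlier compounds suggested that the substituent made little difference in this assay, since bromo in place of hydrogen stayed within the scatter. Nitro breaks that picture, with an 8.2-fold higher number from compound 2 to compound 4 (0.91 log units; beyond the scatter) for nitro in place of hydrogen and a 6.6-fold higher number from compound 3 to compound 4 (0.82 log units; beyond the scatter) for nitro in place of bromo, so this position does respond to what it carries, and the two substituents are not interchangeable there. Nothing available explains why nitro and bromo differ at this position.

As far as these compounds go, it remains open whether this weakening is particular to nitro or would also appear with other groups on the same carbon, such as an amine, a carboxylic acid or a fluoro group. It is also unknown whether nitro would have the same effect on another aromatic carbon of this ring.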